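Replacing the ethylamino group on the fused ring with bromo

The compounds below may be only part of what the source reports. "The series", "measured", "known", "first", "only" and "open" are said of these compounds alone.

Measured compounds:
compound 1 `CCNc1ccc2c(c1)OC(N)=C(C#N)C2c1cccc([N+](=O)[O-])c1` gives 110000000 nM in a functional assay on T47D cells (Homo sapiens) for activation; a lower number here means that less compound is needed, a higher number that more compound is needed for the effect
compound 2 `CCNc1ccc2c(c1)OC(N)=C(C#N)C2c1cc(Br)c(OC)c(OC)c1` gives 14000000 nM in this assay
compound 3 `CCNc1ccc2c(c1)OC(N)=C(C#N)C2c1cc(OC)c(OC)c(OC)c1` gives 49000000 nM in this assay

Compound 2 holds the lowest of these three numbers; compound 3 is nearest with a 3.5-fold higher number from compound 2 to compound 3 (0.54 log units; beyond the scatter), and compound 1 is furthest. Compound 4 `COc1cc(C2C(C#N)=C(N)Oc3cc(Br)ccc32)cc(Br)c1OC` differs from compound 2 by bromo in place of ethylamino on an aromatic carbon. Among the measured compounds shown here, no measured step touches this position: the only measured step, from compound 2 to compound 3, concerns the pendant aryl ring and was modest in size. With nothing to go on, the step to compound 4 is expected to stay close to compound 2, with wide uncertainty, giving a 2.1-fold higher number from compound 2 to compound 4 (0.33 log units; beyond the scatter). Compound 4 is therefore estimated at 30000000 nM, within a range from 5000000 nM to 200000000 nM.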

Compound 4, half-maximal effective concentration: 140000000 nM
The estimate for compound 4 lay 4.7-fold (0.67 log units) below the measured number, and the stated range covers the measured number.
By their numbers in this assay, from the lowest: compound 2; then compound 3; then compounds 1 and 4 (each within the scatter of the next).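

In this assay the position on the fused ring now has a measured step, with a 10-fold higher number from compound 2 to compound 4 (1.00 log units; beyond the scatter) for bromo in place of ethylamino. Among the compounds shown here, this shows that the number responds to a change at this position, whereas the earlier compounds all carried ethylamino here and varied only the pendant aryl ring. No evidence is available to explain this step. The pair cannot separate the loss of ethylamino from the arrival of bromo. Going by these compounds, how a plain amine, a longer chain such as propylamino or a hydroxyl group would read at this position remains open.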